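A few compounds are considered here, and "the series" means these few. Any claim that something is new, unique, unknown or untested is made for them only; others in the source may bear on it.

Compound 1 `COC(=O)[C@H](CC(C)C)NC(=O)c1cnc2ccccc2c1Cl` in an ADME assay on CCRF-CEM cells (Homo sapiens) for cytotoxicity (on this read-out higher numbers stand for lower toxicity in this test and lower numbers for higher toxicity in this test), gives 49.1 uM.
Compound 2 `COC(=O)[C@H](CO)NC(=O)c1cnc2ccccc2c1Cl` gives only a limit of the test, > 100 uM.
Compound 3 `COC(=O)[C@H](CO)NC(=O)c1cnc2cc(Cl)ccc2c1Cl` likewise gives only a limit, > 100 uM.

Two of the three measured compounds share the same core with a small side chain, and on the shared read-out compound 2 stands at the upper limit of the test, where no number is reported (the limit of > 100 uM in this assay, at which 2 of the 3 values shown sit). The measured steps give little to lean on: an at least 2.0-fold higher number from compound 1 to compound 2 (0.30 log units; that floor lies within the scatter), and a step that the two limits leave unreadable from compound 2 to compound 3.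

Compound 4 `COC(=O)[C@H](CO)NC(=O)c1cnc2ccc(F)cc2c1Cl` is the next compound, differing from compound 2 by fluoro in place of hydrogen on an aromatic carbon. Among the measured compounds shown here, the only measured step of a similar kind, the step from compound 2 to compound 3, changed a halogen on an aromatic carbon and could not be read because both ends were limits. On that basis no movement beyond the scatter is expected for compound 4 in this assay, and the estimated step that the limit leaves unreadable from compound 2 to compound 4 is close to none. Compound 4 is therefore expected to come out around 150 uM, within a range of 50 uM to 450 uM, most likely again as a limit rather than a number.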

Compound 4, half-maximal toxic concentration: > 100 uM
Compound 4 gave a limit, no number; the forecaster's own chance of this, stated with the estimate: 70%; the middle value lies beyond the limit too.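

Compound 2 and compound 4 both give a limit rather than a number, so no new step can be read from them: the limit of > 100 uM in this assay, at which 3 of the 4 values shown sit.

From the compounds shown here alone, whether fluoro or chloro in place of hydrogen on an aromatic carbon changes the result in this assay at all remains open.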